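A few compounds are considered here, and "the series" means these few. Any claim that something is new, unique, unknown or untested is made for them only; others in the source may bear on it.

Among the measured compounds shown here, in a functional assay on HEK293 cells for agonist activity at Free fatty acid receptor 1 (Homo sapiens), read by fluorescence and calcium flux, with a stated time of 10 min (a lower number here means that less compound is needed, a higher number that more compound is needed for the effect), compound 1 `CC#C[C@@H](CC(=O)O)c1ccc(OC[C@H]2COc3ccc(Cl)cc3O2)cc1` gives 50 nM, the lowest of the three numbers measured so far. Compound 2 `CC#C[C@@H](CC(=O)O)c1ccc(OC[C@H]2COc3ccc(C)cc3O2)cc1` gives 120 nM, and compound 3 `CC#C[C@@H](CC(=O)O)c1ccc(OC[C@H]2COc3ccc(OC)cc3O2)cc1` gives 130 nM. The steps of a 2.4-fold higher number from compound 1 to compound 2 (0.38 log units; beyond the scatter) and a 2.6-fold higher number from compound 1 to compound 3 (0.41 log units; beyond the scatter) both lie beyond the scatter, while a 1.1-fold higher number from compound 2 to compound 3 (0.03 log units; within the scatter) stays within it. Compound 4 `CC#C[C@@H](CC(=O)O)c1ccc(OC[C@H]2COc3cc(F)c(Cl)cc3O2)cc1` differs from compound 1 in one place: fluoro in place of hydrogen on an aromatic carbon. For the measured compounds named here, none of the measured steps touches this position; each of them swaps the group at the place where compound 1 carries chloro, and compound 4 keeps that chloro. Going by the values given here, with no measured step bearing on the change, a move no larger than the scatter is expected, namely a 1.1-fold lower number from compound 1 to compound 4 (0.05 log units; within the scatter). Compound 4 is therefore estimated at 45 nM, within a range from 20 nM to 110 nM.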

Compound 4, half-maximal effective concentration: 210 nM
Beside the measured number, compound 4's estimate is 4.7-fold (0.67 log units) below it; measured number above the stated range.
By their numbers in this assay, from the lowest: compound 1; then compounds 2, 3 and 4 (each within the scatter of the next).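

Placing a single fluoro ortho to the chloro group gives a 4.2-fold higher number from compound 1 to compound 4 (0.62 log units; beyond the scatter) in this assay, so more compound is needed for the effect. The earlier steps shown here only swapped the group where compound 1 carries chloro; this step shows that with the chloro kept, one added heavy atom at this position also moves the number beyond the scatter. Nothing available here gives a reason for this rise. Still open, from the compounds shown here alone, is whether the rise belongs to fluoro itself or to any group here, as an amine or a nitrile at this position would show. Also open, going by these compounds, is whether fluoro would have the same effect with methyl or methoxy in place of the chloro.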